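Fluoro on the Benzoyl Group of Compound 1

The source may report more compounds than this note shows. Statements on the series, on what has been measured and on what is new or still open speak of the compounds shown alone.

Compound 1 `O=C(CC1S/C(=N\N=C\c2c(-c3ccccc3)[nH]c3ccccc23)NC1=O)c1ccccc1` was tested in an ADME assay on BJ cells (Homo sapiens) for cytotoxicity, read by fluorescence, with a stated time of 24 h (a higher number here means a weaker inhibitor, a lower number a stronger inhibitor), and gives > 50000 nM as its result, which is a limit of the assay and not a number. Compound 3 `CC1S/C(=N\N=C\c2c(-c3ccc(Br)cc3)[nH]c3ccccc23)NC1=O` gives > 50000 nM as its result, also a limit. Compound 2 `CCOC(=O)c1sc(N/N=C/c2c(-c3ccc([N+](=O)[O-])cc3)[nH]c3ccccc23)nc1C` reads 50000 nM as a measured number. Compound 1 therefore stands at the limit of > 50000 nM in this assay, at which 2 of the 3 values shown sit, on this small set.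

Compound 4 `O=C(CC1S/C(=N\N=C\c2c(-c3ccccc3)[nH]c3ccccc23)NC1=O)c1ccc(F)cc1` differs from compound 1 by fluoro in place of hydrogen on an aromatic carbon, turning benzoyl into (4-fluorophenyl)carbonyl (fluoro in place of hydrogen on an aromatic carbon). Going by the values given here, no measured pair shows this change, so no step beyond the scatter is expected in this assay in either direction. The estimated step is a number no higher from compound 1 to compound 4 (the limit leaves the size open) and no more. Compound 4 is expected near 50000 nM within an estimated range of 30000 nM to 80000 nM overall.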

Compound 4, half-maximal inhibitory concentration: > 50000 nM
Compound 4: only a limit was reported; the forecaster's own chance of this, stated with the estimate: 75%; the middle value sits exactly at the limit.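

In this assay, going by these compounds alone, compound 1 and compound 4 each give only a limit of the assay, so no step between them can be read. As far as these compounds go, whether fluoro on the benzoyl group changes the reading at all remains open.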